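This account rests on a few compounds, and the source may have more. Where it says the series, first, only, none or still open, it means among the compounds named here.

Compound 1 `OCC#CCSc1cnc2ccccc2c1SCC#CCO` is the reference point of the series. In a functional assay on P388 cells (Mus musculus) for cytotoxicity, read by MTT assay, with a stated time of 72 h (on this read-out lower numbers stand for stronger inhibition and higher numbers for weaker inhibition), compound 1 gives 5.7 ug/mL, the lowest of the three numbers measured, and both other compounds stand beyond the scatter from it: compound 3 `C#CCSc1c(SCC#CCO)cnc2ccccc12` gives 13.3 ug/mL and compound 2 `C[Se]c1c(SCC#CCO)cnc2ccccc12` gives 19.8 ug/mL. The step of a 2.3-fold higher number from compound 1 to compound 3 (0.37 log units; beyond the scatter) and the step of a 3.5-fold higher number from compound 1 to compound 2 (0.54 log units; beyond the scatter) are both modest; the step of a 1.5-fold lower number from compound 2 to compound 3 (0.17 log units; within the scatter) stays within the scatter, so no order between compound 2 and compound 3 is claimed.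

Compound 4 `C#CCSc1cnc2ccccc2c1SCC#CCO` has not been measured yet. Against compound 1 the change is hydrogen in place of hydroxymethyl on a triple-bonded carbon. The measured step that bears on it is a 2.3-fold higher number from compound 1 to compound 3 (0.37 log units; beyond the scatter), since compound 3 carries the same kind of change, hydrogen in place of hydroxymethyl on a triple-bonded carbon; the step of a 3.5-fold higher number from compound 1 to compound 2 (0.54 log units; beyond the scatter) removes a larger group and is a weaker guide. A modest step upward in this assay, that is a higher number and weaker inhibition, is therefore expected for compound 4, and the expected step is a 2.1-fold higher number from compound 1 to compound 4 (0.32 log units; beyond the scatter). Compound 4 is estimated at 12 ug/mL, with a range from 6 ug/mL to 25 ug/mL; the range is kept wide because a 2.3-fold higher number from compound 1 to compound 3 (0.37 log units; beyond the scatter) rests on a single comparison.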

Compound 4, concentration for 50% inhibition: 4 ug/mL
For compound 4 the middle estimate is 3.0-fold (0.48 log units) above the measured one; the measured number lies below the stated range.
By their numbers in this assay, from the lowest: compounds 4 and 1 (each within the scatter of the next); then compounds 3 and 2 (each within the scatter of the next).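

Cutting hydroxymethyl down to hydrogen on the triple-bonded carbon of this chain gives a 1.4-fold lower number from compound 1 to compound 4 (0.15 log units; within the scatter) in this assay, so at this position the 4-hydroxybut-2-yn-1-yl to propargyl change leaves no difference that can be read, and the hydroxymethyl end is not needed here to hold the number of compound 1. The same change on the other chain of compound 1 gives a 2.3-fold higher number from compound 1 to compound 3 (0.37 log units; beyond the scatter), so in these two pairs the outcome depends on which of the two chains carries it, a distinction that compound 3 alone could not show. No measurement available here accounts for that difference between the two chains.

The compounds shown leave open whether an aminomethyl, a methoxymethyl or a carboxylic acid on the triple-bonded carbon of this chain, or a longer hydroxyalkyl chain in place of hydroxymethyl, would stay within the scatter of compound 1 or move away from it. They also leave open what happens when propargyl stands on both sulfur atoms at once.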